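A few compounds are considered here, and "the series" means these few. Any claim that something is new, unique, unknown or untested is made for them only; others in the source may bear on it.

Compound 1 `C[Si](C)(C)Cn1nnc2c(C(N)=O)ncn2c1=O`: 45600 nM
Compound 2 `NC(=O)c1ncn2c(=O)n(Cc3cccs3)nnc12`: > 50000 nM

Both compounds were tested in a functional assay on U-373MG ATCC cells for inhibition, with U373 MG (Homo sapiens) as the target, read by MTT assay, with a stated time of 7 days; a lower number here means a stronger inhibitor of growth, a higher number a weaker inhibitor of growth. Compound 2 has no numerical value, only a limit of the assay: > 50000 nM. This is the limit of > 50000 nM in this assay, at which 1 of the 2 values shown sits. Among the measured compounds shown here, the only measured step is an at least 1.0-fold higher number from compound 1 to compound 2 (0.04 log units; that floor lies within the scatter), and it gives no more than a floor that lies within the scatter.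

The unmeasured compound 3 `NC(=O)c1ncn2c(=O)n(Cc3ccsc3)nnc12` departs from compound 2 in one place: thiophen-3-yl in place of thiophen-2-yl on a saturated chain carbon bound to an aromatic nitrogen. The two have the same atoms, joined differently. For the measured compounds named here, no measured step compares thiophen-2-yl with thiophen-3-yl directly, so an at least 1.0-fold higher number from compound 1 to compound 2 (0.04 log units; that floor lies within the scatter) bears on this change only indirectly. On that step, no change beyond the scatter is expected in this assay, in either direction. The expected step is a number no higher from compound 2 to compound 3 (the limit leaves the size open). For compound 3 the estimated value is 50000 nM, with an expected range of 30000 nM to 90000 nM.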

Compound 3, concentration for 50% growth inhibition: > 50000 nM
Compound 3: only a limit was reported (the forecaster's own chance of this, stated with the estimate: 65%); the middle value lies on the limit itself.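

In this assay compound 3 returns only a limit of the assay, > 50000 nM, so the change from thiophen-2-yl to thiophen-3-yl on a saturated chain carbon bound to an aromatic nitrogen yields no number. Among the compounds shown here, the step between the two thiophene compounds cannot be read, and the one readable new step is an at least 1.0-fold higher number from compound 1 to compound 3 (0.04 log units; that floor lies within the scatter). What is new is that neither thiophen-2-yl nor thiophen-3-yl brings a measured value into range: the limit of > 50000 nM in this assay, at which 2 of the 3 values shown sit.

Going by these compounds, whether the two ring attachments differ at all remains open, since any difference would lie beyond the reach of this assay. Also open, on these data alone, is whether another group at this place, such as a benzyl group, a longer chain or a chain ending in an amine, would give a clearly lower number than compound 1.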